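Swapping a Methoxyphenyl for a Difluorophenyl

A few compounds are considered here, and "the series" means these few. Any claim that something is new, unique, unknown or untested is made for them only; others in the source may bear on it.

Two measured compounds share one core. Compound 1 `COc1cc(-c2cc(/C=C/C(=O)c3ccc(N)cc3)[nH]n2)cc(OC)c1OC` carries an amino group, and in a functional assay on CCRF-CEM cells (Homo sapiens) for cytotoxicity, read by sulforhodamine B assay, with a stated time of 48 h, tested at 1 uM (a higher number here means a weaker effect of the compound at the concentration tested, a lower number a stronger effect), compound 1 gives 36%. Compound 2 `COc1ccc(C(=O)/C=C/c2cc(-c3cc(OC)c(OC)c(OC)c3)n[nH]2)cc1` carries a methoxy group in its place, and in this assay compound 2 gives 62%. Within the data shown here, the only measured step is a number 26 percentage points higher from compound 1 to compound 2 (beyond the scatter), which leaves compound 2 as the higher, weaker-acting of the two numbers. Compound 3 `COc1cc(-c2cc(/C=C/C(=O)c3ccc(F)c(F)c3)[nH]n2)cc(OC)c1OC` differs from compound 2 by 3,4-difluorophenyl in place of 4-methoxyphenyl on a carbonyl carbon. Among the measured compounds shown here, the step from compound 1 to compound 2 bears on this change only in part: it altered the same group, yet fluorines have no precedent here. That step was modest and went upward when methoxy replaced amino, so removing the methoxy is expected to move the number modestly downward, with wide uncertainty. For compound 3 the estimate is 48%, within 28% to 72%, an expected step of a number 14 percentage points lower from compound 2 to compound 3 (beyond the scatter).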

Compound 3, a percentage reported as activity, at one concentration (the size of the read-out at that concentration, not a potency): 91%
Compound 3: the middle estimate sits 43 percentage points below what was measured; measured number above the stated range.
By their numbers in this assay, from the lowest: compound 1; then compound 2; then compound 3.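

In this assay, among these compounds, the group on the carbonyl carbon proves able to shift the number much further than the first pair of compounds showed. Placing 3,4-difluorophenyl in place of 4-methoxyphenyl gives a number 29 percentage points higher from compound 2 to compound 3 (beyond the scatter) and placing it in place of 4-aminophenyl gives a number 55 percentage points higher from compound 1 to compound 3 (beyond the scatter) so that, of the three groups seen at this place, 3,4-difluorophenyl leaves the weakest effect. Nothing at hand explains this rise.

Among the compounds shown here, with only three groups compared, it stays open whether a single fluorine on the ring would behave like the pair, and how a hydroxyl, a chlorine or a dimethylamino group would compare with the amino group of compound 1. These readings at one concentration also leave open how the compounds would rank across a range of concentrations.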